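Compound 1 to compound 4: amide nitrogen change

The source may hold more compounds than are shown below. What is called first, only, known or untested is meant among the compounds shown, and "the series" means these compounds.

Measured in a functional assay on PC-3 cells (Homo sapiens) for antiproliferative activity, read by MTT assay, with a stated time of 72 h (on this read-out lower numbers stand for stronger inhibition and higher numbers for weaker inhibition), each entry a limit and not a number:
compound 1 `CCn1c(C(=O)NCc2ccc(OC)cc2)ccc1C(CC)(CC)c1ccc(C#CC(O)(CC)CC)c(C)c1`: > 50000 nM
compound 2 `CCn1c(C(=O)On2nnc3ccccc32)ccc1C(CC)(CC)c1ccc(C#CC(O)(CC)CC)c(C)c1`: > 50000 nM
compound 3 `CCCCC(=O)c1ccc(C(CC)(CC)c2ccc(C#CC(O)(CC)CC)c(C)c2)n1CC`: > 50000 nM

Compound 1 stands at > 50000 nM, which is a limit only. The whole measured set sits at the same place: the limit of > 50000 nM in this assay, at which 3 of the 3 values shown sit.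

Not yet measured is compound 4 `CCn1c(C(=O)N[C@H](C(=O)O)C(C)C)ccc1C(CC)(CC)c1ccc(C#CC(O)(CC)CC)c(C)c1`. It differs from compound 1 as follows: 1-carboxy-2-methylpropyl in place of 4-methoxybenzyl on an amide-type nitrogen. In words, 1-carboxy-2-methylpropyl replaces 4-methoxybenzyl on an amide-type nitrogen.

For the measured compounds named here, three measured steps bear on this change, all of them altering what sits on the carbonyl carbon: a step that the two limits leave unreadable from compound 1 to compound 2, a step that the two limits leave unreadable from compound 1 to compound 3 and a step that the two limits leave unreadable from compound 2 to compound 3. None of them gives a size or a direction, so no measured effect can be carried over to compound 4.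

The expectation rests only on the limit of > 50000 nM in this assay, at which 3 of the 3 values shown sit: no step beyond the scatter is expected in this assay, and no direction can be given. The expected step is a number no higher from compound 1 to compound 4 (the limit leaves the size open). A further report of only a limit is the most likely outcome for compound 4. Compound 4 is estimated at 50000 nM, with an expected range of 15000 nM to 100000 nM.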

Compound 4, half-maximal inhibitory concentration: 5000 nM
Estimate against measurement, compound 4: 10-fold (1.00 log units) above; measured number outside the range, below it.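

In this assay, the substituent on the amide-type nitrogen can move the read-out: 1-carboxy-2-methylpropyl in place of 4-methoxybenzyl gives an at least 10-fold lower number from compound 1 to compound 4 (1.00 log units; beyond the scatter). The change also separates compound 4 from the two other carbonyl variations, with an at least 10-fold lower number from compound 3 to compound 4 (1.00 log units; beyond the scatter) and an at least 10-fold lower number from compound 2 to compound 4 (1.00 log units; beyond the scatter), whereas the steps among compound 1, compound 2 and compound 3 cannot be read. Compound 4 is the only member of the set with a number instead of a limit: the limit of > 50000 nM in this assay, at which 3 of the 4 values shown sit.

All three steps start from a limit, so each gives only a minimum size, and the true distance from compound 4 to the other compounds stays open; the change also removes an aromatic ring while bringing in a carboxylic acid, an isopropyl branch and a defined stereocentre, so the compounds shown do not tell which of these parts goes with the lower number. Also open, on these data alone, is whether a methyl ester in place of the carboxylic acid, the opposite configuration at the stereocentre, or a 4-methoxybenzyl group carrying a carboxylic acid would keep the number of compound 4.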